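Chain-to-aryl swap on the ether side of compound 2

The source may hold more compounds than are shown below. What is called first, only, known or untested is meant among the compounds shown, and "the series" means these compounds.

Two compounds of the shared core have numbers in an assay on cells for inhibition of Amine oxidase [flavin-containing] A (Homo sapiens), read by Amplex Red, with stated times of 30 min and 45 min (on this read-out lower numbers stand for stronger inhibition and higher numbers for weaker inhibition), so far. Compound 1 `C#CCCCOc1ccc2cc(NC(C)=O)c(=O)oc2c1` gives 930 nM in this assay, and compound 2 `C#CCCCCOc1ccc2cc(NC(C)=O)c(=O)oc2c1` gives 66.8 nM. Compound 2 thus stands at the lower end of the two numbers, and the single step shown, a 14-fold lower number from compound 1 to compound 2 (1.14 log units; beyond the scatter), is a large one, so lengthening the chain by one carbon moved the number well beyond the scatter.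

Compound 3 `CC(=O)Nc1cc2ccc(OCc3cccc(Cl)c3)cc2oc1=O` is the next member awaiting a number in this assay. The change from compound 2 is 3-chlorophenyl in place of pent-4-yn-1-yl on a saturated chain carbon bound to an oxygen on an aromatic ring. Among the measured compounds shown here, no measured step covers an exchange of an alkyne chain for an aromatic ring at this position; the only step available concerns chain length alone, and the sensitivity of this assay to it means the expected outcome carries a wide spread. On that basis the number for compound 3 is estimated at 200 nM, with a range of 30 nM to 2000 nM. The step this estimate implies is a 3.0-fold higher number from compound 2 to compound 3 (0.48 log units; beyond the scatter), expected to be modest and uncertain in direction.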

Compound 3, half-maximal inhibitory concentration: 62.7 nM
Beside the measured number, compound 3's estimate is 3.2-fold (0.50 log units) above it; the measured number falls inside the stated range.
By their numbers in this assay, from the lowest: compounds 3 and 2 (each within the scatter of the next); then compound 1.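

In this assay, 3-chlorophenyl in place of pent-4-yn-1-yl on a saturated chain carbon bound to an oxygen on an aromatic ring gives a 1.1-fold lower number from compound 2 to compound 3 (0.03 log units; within the scatter), so a triple bond in this group is not needed for a number in this range, and an aromatic ring of carbon only serves as well as the chain of compound 2. Set against but-3-yn-1-yl, the same 3-chlorophenyl gives a 15-fold lower number from compound 1 to compound 3 (1.17 log units; beyond the scatter), a large step of about the same size as the one from added chain length, a 14-fold lower number from compound 1 to compound 2 (1.14 log units; beyond the scatter), so two quite different groups at this place both reach the low end of the numbers shown. Nothing available explains why the alkyne chain and the chlorinated aromatic group read alike.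

The compounds shown leave open whether the chlorine contributes to the number for compound 3, a question that a plain benzyl group would answer. They also leave open whether the effect of chain length continues beyond hex-5-yn-1-yl, which a longer alkyne chain would test, and whether a saturated chain without the triple bond would read the same.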